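Shortening a Side Chain: From Compound 2 to Compound 3

The source may report more compounds than this note shows. Statements on the series, on what has been measured and on what is new or still open speak of the compounds shown alone.

Measured so far:
compound 1 `CNc1nnc(Cn2c(=O)oc3ccc(C)cc32)s1` — 21.4%
compound 2 `CCCn1c(Cn2c(=O)oc3ccc(C)cc32)n[nH]c1=S` — 24.1%

In a functional assay on the whole organism for inhibition, with Mus musculus as the target, read by paw edema, with a stated time of 180 min, at a dose of 100 mg/kg by the oral route (a higher number here means a stronger effect of the compound at the dose given, a lower number a weaker effect), compound 2 gives 24.1% and compound 1 gives 21.4%. Of these two numbers, that of compound 2 is the higher, but only by a margin within the usual scatter, so it does not stand apart from compound 1. Compound 3 `Cc1ccc2oc(=O)n(Cc3n[nH]c(=S)n3C)c2c1` is not yet measured. It differs from compound 2 by hydrogen in place of ethyl on a saturated chain carbon bound to an aromatic nitrogen. For the measured compounds named here, no measured pair shows what such a change does, so nothing here argues for a shift in this assay beyond the scatter in either direction. Compound 3 is therefore expected to give about 22%, between 10% and 34%. The implied step a number 2.1 percentage points lower from compound 2 to compound 3 (within the scatter) is expected to stay within the scatter.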

Compound 3, a percentage reported as inhibition, in the whole organism at one dose (the size of the read-out at that dose, not a potency): 11.8%
Beside the measured number, compound 3's estimate is 10.2 percentage points above it, and the stated range covers the measured number.
By their numbers in this assay, from the lowest: compounds 3, 1 and 2 (each within the scatter of the next, the first and the last beyond it).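

In this assay, for the compounds shown here, this is the first pair differing in one place, and it shows that this position is not indifferent: hydrogen in place of ethyl on a saturated chain carbon bound to an aromatic nitrogen, or propyl to methyl read one bond further out, gives a number 12.3 percentage points lower from compound 2 to compound 3 (beyond the scatter) in this single pair. Nothing measured here gives a reason for this step. Open, going by these compounds, is whether a butyl chain would change the effect further, and whether an amine at the end of the chain would keep it.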